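A few compounds are considered here, and "the series" means these few. Any claim that something is new, unique, unknown or untested is made for them only; others in the source may bear on it.

Measured so far in a functional assay on PC-9 cells (Homo sapiens) for inhibition, read by MTT assay, with a stated time of 48 h, tested at 10 uM; a higher number here means more inhibition at the concentration tested (going by the name of the read-out), a lower number less inhibition:
compound 1 `COc1ccc(F)cc1Nc1cc(NC(=O)Nc2c(Cl)cccc2Cl)ncn1` gives 85.5%
compound 2 `COc1cc(NC(=O)Nc2cc(Nc3ccc(C)c(C)c3)ncn2)cc(OC)c1` gives 66%
compound 3 `COc1cc(NC(=O)Nc2cc(Nc3cc(F)ccc3OC)ncn2)cc(OC)c1` gives 59.5%

Compound 1 stands highest of the three in this assay; the gap to compound 2 lies beyond the scatter, and the step of a number 26 percentage points lower from compound 1 to compound 3 (beyond the scatter) is the largest one seen, following the swap of the aryl on the amide-type nitrogen. Within the data shown here, the only step that touches the nitrogen on the aromatic ring is a number 6.5 percentage points lower from compound 2 to compound 3 (within the scatter), which lies within the scatter, so the anilines tried so far have not moved the read-out in a way that can be trusted.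

Compound 4 `COc1ccc(Nc2cc(NC(=O)Nc3c(Cl)cccc3Cl)ncn2)cc1C` keeps the 2,6-dichlorophenyl urea of compound 1 and differs from it as follows: 4-methoxy-3-methylphenyl in place of 5-fluoro-2-methoxyphenyl on a nitrogen on an aromatic ring. Among the measured compounds shown here, the one comparable step was small, so for compound 4 a step within the scatter is expected, a number 1.5 percentage points lower from compound 1 to compound 4 (within the scatter), with a slight lean upward given the direction of the step from compound 2 to compound 3. Compound 4 is expected to give about 84% in this assay, within 68% to 96%.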

Compound 4, a percentage reported as inhibition, at one concentration (the size of the read-out at that concentration, not a potency): 80.1%
Compound 4: the middle estimate sits 3.9 percentage points above what was measured; measured number inside the range.
By their numbers in this assay, from the lowest: compounds 3 and 2 (each within the scatter of the next); then compounds 4 and 1 (each within the scatter of the next).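

With the 2,6-dichlorophenyl urea held fixed, the aryl on a nitrogen on an aromatic ring changes and this assay gives a number 5.4 percentage points lower from compound 1 to compound 4 (within the scatter). The earlier reading at this position rested on one pair carrying the 3,5-dimethoxyphenyl urea, a number 6.5 percentage points lower from compound 2 to compound 3 (within the scatter), and it now holds with a second urea aryl, so at both urea aryls this nitrogen substituent has yet to produce a step beyond the scatter. Losing the fluorine of 5-fluoro-2-methoxyphenyl and gaining the methyl of 4-methoxy-3-methylphenyl leaves the read-out within the scatter, and no measured evidence bears on why.

As far as these compounds go, all the groups at this position are substituted phenyls, so it remains open whether the read-out stays flat with a morpholine or an aliphatic amine chain there. From the compounds shown here alone, it also remains open whether the urea aryl gap seen between compound 1 and compound 3 carries over to the 4-methoxy-3-methylphenyl series.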